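The compounds below may be only part of what the source reports. "The series", "measured", "known", "first", "only" and "open" are said of these compounds alone.

In a functional assay on the whole organism for inhibition, with Mus musculus as the target, in the maximal electroshock model (on this read-out lower numbers stand for an effect already at smaller amounts and higher numbers for an effect only at larger amounts of compound), compound 3 (`Nc1ccc(C(=O)NCc2ccccc2)cc1`) gives 23.3 mg/kg as its value. Compound 1 (`CCCCCNC(=O)c1ccc(N)cc1`) at 43 mg/kg lies within the scatter of compound 3. Compound 2 (`CCCN(CCC)C(=O)c1ccc(N)cc1`) at 61.7 mg/kg lies beyond the scatter of compound 3, on the higher side.

Compound 4 (`CN(Cc1ccccc1)C(=O)c1ccc(N)cc1`) differs from compound 3 at one place (methyl in place of hydrogen on an amide-type nitrogen), with methyl in place of hydrogen on an amide-type nitrogen. Among the compounds with values here, no measured pair isolates this change. Within the data shown here, the only guide is compound 2 at 61.7 mg/kg as the one measured compound without the amide hydrogen. The expected 1.5-fold higher number from compound 3 to compound 4 (0.19 log units; within the scatter) points toward a higher number and probably stays within the scatter. For compound 4 the estimated value is 36 mg/kg with an expected range from 18 mg/kg to 70 mg/kg in this measurement.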

Compound 4, dose for half-maximal effect: 52.6 mg/kg
For compound 4 the middle estimate is 1.5-fold (0.16 log units) below the measured one; low and high end bracket the measured number.
By their numbers in this assay, from the lowest: compounds 3, 1, 4 and 2 (each within the scatter of the next, the first and the last beyond it).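

Methyl in place of hydrogen on the amide-type nitrogen gives in this assay a 2.3-fold higher number from compound 3 to compound 4 (0.35 log units; beyond the scatter) as the first one-place comparison in the series. The step is modest but beyond the scatter, so this position is not neutral to the change in this read-out. Nothing measured here bears on the reason for the step.

From the compounds shown here alone, whether an ethyl or a longer chain on this nitrogen shifts the number further remains open. Going by these compounds, the same methyl change on compound 1 also remains open, so the step rests on one pair alone.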